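Title: A larger substituent on the aromatic nitrogen of compound 1

A few compounds are considered here, and "the series" means these few. Any claim that something is new, unique, unknown or untested is made for them only; others in the source may bear on it.

Measured so far:
compound 1 `CN(C)C(=O)CN1CCC(c2cc3c(-c4ccc(=O)n(C)c4)ccnc3[nH]2)CC1`: < 1 uL/min
compound 2 `COc1cc(F)ccc1-c1ccnc2[nH]c(C3CCN(CC(=O)N(C)C)CC3)cc12`: 38 uL/min

Compound 1 `CN(C)C(=O)CN1CCC(c2cc3c(-c4ccc(=O)n(C)c4)ccnc3[nH]2)CC1` reaches only a limit in an ADME assay on cells (Hepatocyte, Rattus norvegicus) for metabolic stability (on this read-out lower numbers stand for slow clearance and higher numbers for fast clearance), < 1 uL/min. Compound 2 `COc1cc(F)ccc1-c1ccnc2[nH]c(C3CCN(CC(=O)N(C)C)CC3)cc12` gives 38 uL/min in this assay. Among the measured compounds shown here, the single measured step, an at least 38-fold higher number from compound 1 to compound 2 (1.57 log units; beyond the scatter), exchanges one aromatic group for another on the shared core and says nothing about the change now considered. Compound 3 `CN(C)C(=O)CN1CCC(c2cc3c(-c4ccc(=O)n(CCC5CCOCC5)c4)ccnc3[nH]2)CC1` differs from compound 1 by (oxan-4-yl)methyl in place of hydrogen on a saturated chain carbon bound to an aromatic nitrogen. For the measured compounds named here, no measured step touches this change, so the expectation rests on compound 1 alone, where the limit of < 1 uL/min in this assay, at which 1 of the 2 values shown sits, leaves room only toward higher numbers. Compound 3 is therefore expected at 5 uL/min, between 1 uL/min and 25 uL/min, an estimated step of an at least 5.0-fold higher number from compound 1 to compound 3 (0.69 log units; beyond the scatter).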

Compound 3, intrinsic clearance in a liver preparation (reported as CLH), per the amount of preparation that the assay uses: 14 uL/min
Compound 3: the middle estimate sits 2.8-fold (0.45 log units) below what was measured, and the stated range covers the measured number.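

In this assay, (oxan-4-yl)methyl in place of hydrogen on a saturated chain carbon bound to an aromatic nitrogen gives an at least 14-fold higher number from compound 1 to compound 3 (1.14 log units; beyond the scatter). This shows that the read-out responds to a change at this position alone, with the aromatic group of compound 1 otherwise kept. Compound 1 stands at a limit of the assay, so the full size of the step cannot be read: the limit of < 1 uL/min in this assay, at which 1 of the 3 values shown sits.

The compounds shown leave open how a plain ethyl group, a 2-cyclohexylethyl group without the ring oxygen, or a chain ending in an amine would read in this assay.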